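A Methyl Sulfonamide Set Beside Three Inactive Aryl Analogues

A few compounds are considered here, and "the series" means these few. Any claim that something is new, unique, unknown or untested is made for them only; others in the source may bear on it.

Compound 1 `O=S(=O)(Nc1ccc(-c2nc3ccccc3o2)cc1)c1ccccc1Cl` — in an assay on isolated protein for inhibition of malate dehydrogenase, mitochondrial (Sus scrofa), with stated times of 45 min and 30 min (a higher number here means a weaker inhibitor, a lower number a stronger inhibitor), compound 1 gives > 63000 nM, a limit.
Compound 2 `Cc1ccccc1S(=O)(=O)Nc1ccc2oc(-c3ccccc3)nc2c1` — in this assay compound 2 gives > 63000 nM, a limit.
Compound 3 `O=S(=O)(Nc1ccc2oc(-c3ccccc3)nc2c1)c1cccc(F)c1` — in this assay compound 3 gives > 63000 nM, a limit.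

Compound 1 stands at the limit of this assay, so only an upper bound on its strength is known. The one step among the measured compounds, a step that the two limits leave unreadable from compound 2 to compound 3, is unreadable, since both ends are limits; all that is shown is the limit of > 63000 nM in this assay, at which 3 of the 3 values shown sit. Compound 4 `CS(=O)(=O)Nc1ccc(-c2nc3ccccc3o2)cc1` is a new variant of compound 1: methyl in place of 2-chlorophenyl on a sulfonyl sulfur. For the measured compounds named here, no measured step bears on this change, because a step that the two limits leave unreadable from compound 2 to compound 3 concerns a different exchange on the same sulfonyl sulfur and is itself unreadable. Given that compound 1 sits at a limit, the step that the limit leaves unreadable from compound 1 to compound 4 is expected to leave compound 4 at or beyond that limit, with no movement readable beyond the scatter. Compound 4 is therefore estimated at 100000 nM, within a range from 30000 nM to 400000 nM, most likely reported again only as a limit.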

Compound 4, half-maximal inhibitory concentration: > 63000 nM
Compound 4: a limit, no number (the forecaster's own chance of this, stated with the estimate: 85%); the middle value is on the limit's open side.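

In this assay compound 4 gives > 63000 nM, a limit, so no step can be read from compound 1 to compound 4. The compounds shown leave open how the groups on the sulfonyl sulfur rank, and whether any of these compounds has a measurable strength: the limit of > 63000 nM in this assay, at which 4 of the 4 values shown sit.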